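This account rests on a few compounds, and the source may have more. Where it says the series, first, only, none or still open, it means among the compounds named here.

Compound 3 `CCN(CC)CN1C(=O)/C(=N/NC(=S)Nc2ccccc2)c2ccccc21` is the parent of this small set, carrying an unsubstituted phenyl on the thiourea. In an ADME assay on MDCK cells (Canis lupus familiaris) for cytotoxicity (a higher number here means that more compound is tolerated, a lower number that less compound is tolerated), compound 3 gives 800 nM. That places it level with compound 1 `CCN(CC)CN1C(=O)/C(=N/NC(=S)Nc2ccc(Cl)cc2)c2ccccc21`, which gives 800 nM in this assay; the two together sit at the bottom of the three numbers, and the step of no change at the digits printed from compound 1 to compound 3 (within the scatter) confirms that swapping chloro for hydrogen left the read-out unchanged. Compound 2 `CCN(CC)CN1C(=O)/C(=N/NC(=S)Nc2ccc(OC)cc2)c2ccccc21`, which gives 4000 nM, is the one outlier, as the step of a 5.0-fold lower number from compound 2 to compound 3 (0.70 log units; beyond the scatter) shows.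

Compound 4 `CCN(CC)CN1C(=O)/C(=N/NC(=S)Nc2ccc(C)cc2)c2ccccc21` is the next member, and it differs from compound 3 by methyl in place of hydrogen on an aromatic carbon. Within the data shown here, two measured steps bear on this: a chloro at the same ring carbon produced no change beyond the scatter from compound 1 to compound 3, whereas a methoxy there produced a modest rise, a 5.0-fold higher number from compound 1 to compound 2 (0.70 log units; beyond the scatter). A single methyl group is neither of those, so only a small shift, if any, is anticipated in this assay, and no clear direction can be read from so few examples.

For compound 4 the expected value is 1000 nM, with a range from 400 nM to 4000 nM. This would correspond to an expected step of a 1.3-fold higher number from compound 3 to compound 4 (0.10 log units; within the scatter).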

Compound 4, minimum cytotoxic concentration: 800 nM
Compound 4: the middle estimate sits 1.3-fold (0.10 log units) above what was measured, and the stated range covers the measured number.
By their numbers in this assay, from the lowest: compounds 1, 3 and 4 (each within the scatter of the next); then compound 2.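

In this assay the step of no change at the digits printed from compound 3 to compound 4 (within the scatter) adds methyl to chloro as a group at this ring carbon that leaves the read-out level with the unsubstituted parent. The step of no change at the digits printed from compound 1 to compound 4 (within the scatter) shows that methyl and chloro cannot be told apart here, although they are different groups. The methoxy compound now stands apart from three compounds instead of two, as the step of a 5.0-fold lower number from compound 2 to compound 4 (0.70 log units; beyond the scatter) shows, so among hydrogen, chloro, methyl and methoxy at this carbon, methoxy alone goes against an otherwise flat picture.

As far as these compounds go, what remains open is whether the methoxy result is particular to that one group or extends to relatives such as hydroxyl, ethoxy or dimethylamino at the same carbon. A larger group such as tert-butyl, a carboxylic acid, or any of these groups placed on another carbon of the ring could also give a different answer. No supporting data are available to explain why methoxy differs from the other three groups.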